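This account rests on a few compounds, and the source may have more. Where it says the series, first, only, none or still open, it means among the compounds named here.

Working notes on the series. All four compounds share one core and differ only in the group carried on an aromatic carbon. Compound 1 `O=c1cc(Cn2cc(C3CC3)nn2)c2ccc(O)cc2o1` carries cyclopropyl; in a functional assay on SW-620 cells (Homo sapiens) for inhibition, read by MTT assay, with a stated time of 72 h (on this read-out lower numbers stand for stronger inhibition and higher numbers for weaker inhibition), compound 1 gives only a limit, > 100000 nM. Compound 2 `O=c1cc(Cn2cc(CCCCl)nn2)c2ccc(O)cc2o1` carries 3-chloropropyl, and in this assay compound 2 gives 59800 nM. Compound 3 `O=c1cc(Cn2cc(CCCCO)nn2)c2ccc(O)cc2o1` carries 4-hydroxybutyl; in this assay compound 3 gives only a limit, > 100000 nM. Compound 3 thus sits at the top edge of the numbers shown, sharing that position with compound 1 (the limit of > 100000 nM in this assay, at which 2 of the 3 values shown sit). The measured steps are all small or unreadable: an at least 1.6-fold lower number from compound 1 to compound 2 (0.22 log units; that floor lies within the scatter), a step that the two limits leave unreadable from compound 1 to compound 3 and an at least 1.6-fold higher number from compound 2 to compound 3 (0.22 log units; that floor lies within the scatter); none of them is beyond the scatter.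

Compound 4 `O=c1cc(Cn2cc(CCc3ccccc3)nn2)c2ccc(O)cc2o1` differs from compound 3 by phenyl in place of 2-hydroxyethyl on a saturated chain carbon, two bonds along the chain from an aromatic carbon. The step that bears on it is an at least 1.6-fold higher number from compound 2 to compound 3 (0.22 log units; that floor lies within the scatter), which shows that replacing the hydroxyl-bearing end of the chain with chloro went together with a lower number, but only as a floor within the scatter. The new group removes the hydroxyl end entirely, so compound 4 is expected to give a number nearer that of compound 2, 59800 nM, than that of compound 3, though the size cannot be read from the steps shown. Compound 4 is estimated at 40000 nM, within 10000 nM to 150000 nM. The expected step is an at least 2.5-fold lower number from compound 3 to compound 4 (0.39 log units; beyond the scatter).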

Compound 4, half-maximal inhibitory concentration: 84400 nM
Compound 4: middle estimate off by 2.1-fold (0.32 log units), on the low side; the range from low to high includes it.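

Compound 4 shows that phenethyl on the aromatic carbon gives a readable number in this assay, as 3-chloropropyl does, whereas 4-hydroxybutyl and cyclopropyl give only limits; the two steps against those limits are floors of unknown size: an at least 1.1-fold lower number from compound 3 to compound 4 (0.07 log units; that floor lies within the scatter) and an at least 1.1-fold lower number from compound 1 to compound 4 (0.07 log units; that floor lies within the scatter). Phenyl in place of chloromethyl gives a 1.4-fold higher number from compound 2 to compound 4 (0.15 log units; within the scatter), so 3-chloropropyl and phenethyl are not told apart in this read-out, even though one carries a six-membered aromatic ring and the other does not. The series as a whole still yields only two readable numbers, and the other two compounds give limits rather than numbers: the limit of > 100000 nM in this assay, at which 2 of the 4 values shown sit.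

The compounds shown leave open whether an amine or a carboxylic acid in place of the phenyl of compound 4 would give a step beyond the scatter. Also open, on these data alone, is whether a longer chain carrying the same phenyl, such as 4-phenylbutyl, would differ from compound 4 by more than the scatter.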